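The compounds below may be only part of what the source reports. "The series", "measured", "known", "first", "only" and "open" are said of these compounds alone.

Values measured in a functional assay on RS4-11 cells (Homo sapiens) for inhibition, read by CCK-8 assay, with a stated time of 48 h, tested at 20 uM; a higher number here means more inhibition of growth at the concentration tested, a lower number less inhibition of growth
- Compound 1 `N#C/C(=C\c1ccccc1OS(=O)(=O)c1ccc([N+](=O)[O-])cc1)C(=O)Nc1nnc(-c2cccs2)s1` gives 40%
- Compound 2 `COc1ccc(Cc2nnc(NC(=O)/C(C#N)=C/c3ccccc3OS(=O)(=O)c3ccc([N+](=O)[O-])cc3)s2)cc1` gives 70%
- Compound 3 `N#C/C(=C\c1ccccc1OS(=O)(=O)c1ccc([N+](=O)[O-])cc1)C(=O)Nc1nnc(Cc2cccc(F)c2)s1` gives 65%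

Compound 3, at 65%, lies within the scatter of compound 2 and clearly higher than compound 1. Compound 4 `Cc1ccc(Cc2nnc(NC(=O)/C(C#N)=C/c3ccccc3OS(=O)(=O)c3ccc([N+](=O)[O-])cc3)s2)cc1` differs from compound 3 in one place: 4-methylphenyl in place of 3-fluorophenyl on a saturated chain carbon bound to an aromatic carbon. It carries 4-methylphenyl in place of 3-fluorophenyl on a saturated chain carbon bound to an aromatic carbon.

The closest measured change, at this same place, is a number 5 percentage points lower from compound 2 to compound 3 (within the scatter). The larger steps, a number 30 percentage points higher from compound 1 to compound 2 (beyond the scatter) and a number 25 percentage points higher from compound 1 to compound 3 (beyond the scatter), replaced thiophen-2-yl, a change not repeated here. The expected step is therefore small, within the scatter: a number 2 percentage points higher from compound 3 to compound 4 (within the scatter). For compound 4 the estimated value is 67%, with an expected range from 52% to 80%.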

Compound 4, percent growth inhibition at one concentration: 64%
Beside the measured number, compound 4's estimate is 3 percentage points above it; measured number inside the range.
By their numbers in this assay, from the lowest: compound 1; then compounds 4, 3 and 2 (each within the scatter of the next).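

In this assay, 4-methylphenyl in place of 3-fluorophenyl gives a number 1 percentage points lower from compound 3 to compound 4 (within the scatter), and methyl in place of methoxy on an aromatic carbon gives a number 6 percentage points lower from compound 2 to compound 4 (within the scatter), so these three benzyl groups read alike. 4-Methylbenzyl in place of thiophen-2-yl gives a number 24 percentage points higher from compound 1 to compound 4 (beyond the scatter), making this the third benzyl group to stand clear of thiophen-2-yl. Nothing available explains why these groups read alike. Still open, as far as these compounds go, is whether a benzyl group bearing an amine or a carboxylic acid, or a longer chain, would hold this level.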